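The compounds below may be only part of what the source reports. "The series", "measured", "known", "first", "only" and "open" are said of these compounds alone.

Measured compounds:
- compound 1, `ClCc1ccccc1Cn1cnc2c(Cl)nc(Cl)nc21`: 90 nM
- compound 2, `ClCc1ccc(Cn2cnc3c(Cl)nc(Cl)nc32)cc1`: 4570 nM

Both compounds were tested in a functional assay on CCRF-CEM cells (Homo sapiens) for cytotoxicity, read by sulforhodamine B assay, with a stated time of 48 h; a higher number here means a weaker inhibitor of growth, a lower number a stronger inhibitor of growth. Compound 1, with the chloromethyl group on the aromatic ring next to the point where the benzyl chain joins the core, gives 90 nM and stands as the lowest of the two numbers. Compound 2 gives 4570 nM, a much higher number, and the gap between the two lies well beyond the usual scatter of this assay.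

Compound 3, `Nc1nc(Cl)c2ncn(Cc3ccccc3CCl)c2n1`, has not yet been measured. It keeps the whole of compound 1 except for one change: amino in place of chloro on an aromatic carbon — amino in place of chloro, on an aromatic carbon of the core that sits between two ring nitrogen atoms. For the measured compounds named here, no measured pair in this set shows what such an exchange on the core does, so the expectation rests on compound 1 alone. The chloromethyl-bearing benzyl part, which distinguishes compound 1 from compound 2, is untouched, and the estimated step from compound 1 to compound 3 is therefore modest, a 2.2-fold higher number from compound 1 to compound 3 (0.35 log units; beyond the scatter), leaning toward a somewhat higher number. Compound 3 is expected to give about 200 nM, within a range from 50 nM to 1000 nM.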

Compound 3, concentration for total growth inhibition: > 100000 nM
Compound 3: no number, only a limit; the forecaster's own chance of this, stated with the estimate: 5%; middle value at least 500-fold (2.69 log units) from the limit.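

In this assay compound 3 gives > 100000 nM, which is a limit of the assay and not a number. With the chloromethyl-bearing benzyl part left unchanged, amino in place of chloro on this aromatic carbon, between two ring nitrogen atoms, gives an at least 1100-fold higher number from compound 1 to compound 3 (3.04 log units; beyond the scatter). The earlier compounds differed only in the benzyl part, whereas this result shows that the benzyl part of compound 1 does not by itself preserve growth inhibition and that this single exchange on the core can remove nearly all of it, with the full size of the step left unknown: the limit of > 100000 nM in this assay, at which 1 of the 3 values shown sits.

What a methoxy group, a methylamino group or a plain hydrogen would do on this carbon stays open, so the compounds shown cannot separate the effect of losing chloro from that of gaining amino. Also open, as far as these compounds go, are whether the same exchange would act alike with the benzyl part of compound 2, and what the remaining chloro group on the core contributes.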